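Fluorine Placement on a Benzyl Arm and Liver Cell Growth

This account rests on a few compounds, and the source may have more. Where it says the series, first, only, none or still open, it means among the compounds named here.

Measured compounds:
compound 1 `Fc1ccccc1CSc1nnc(-c2cnccn2)o1`, 12500 nM;
compound 2 `Fc1cccc(F)c1CSc1nnc(-c2cnccn2)o1`, 17100 nM;
compound 3 `Fc1ccc(CSc2nnc(-c3cnccn3)s2)cc1`, 10100 nM.

In a functional assay on HepG2 cells (Homo sapiens) for antiproliferative activity, read by MTT assay, with a stated time of 48 h (a higher number here means a weaker inhibitor, a lower number a stronger inhibitor), compound 1 gives 12500 nM. Compound 2 carries one change against compound 1, (fluoro in place of hydrogen on an aromatic carbon), and this gave a 1.4-fold higher number from compound 1 to compound 2 (0.14 log units; within the scatter). Compound 3 sits on a different core; how that core differs from the core of compound 1 is not broken down here. In this assay compound 3 gives 10100 nM, and the values of compound 1 and compound 3 lie within the scatter of each other, as do those of compound 2 and compound 3.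

Compound 4 `Fc1ccc(CSc2nnc(-c3cnccn3)s2)c(F)c1` is not yet measured. It stands to compound 3 as compound 2 stands to compound 1: fluoro in place of hydrogen on an aromatic carbon. The two changes occur at places described in the same words, so this is the same change seen once more, on the other core. Because the earlier step was a 1.4-fold higher number from compound 1 to compound 2 (0.14 log units; within the scatter), a step of similar size is expected here, a 1.3-fold higher number from compound 3 to compound 4 (0.11 log units; within the scatter). Compound 4 is therefore estimated at 13000 nM in this assay, expected between 6000 nM and 28000 nM.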

Compound 4, half-maximal inhibitory concentration: 9630 nM
The estimate for compound 4 lay 1.3-fold (0.13 log units) above the measured number; low and high end bracket the measured number.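

In this assay, adding the fluoro group gave a 1.0-fold lower number from compound 3 to compound 4 (0.02 log units; within the scatter), and this step, like the earlier one, stays within the scatter. The two steps also do not differ from each other beyond what two such measurements allow: the same change on two cores in this assay, a 1.4-fold higher number (0.14 log units; within the scatter) from compound 1 to compound 2 and a 1.0-fold lower number (0.02 log units; within the scatter) from compound 3 to compound 4, 1.4-fold (0.16 log units) apart, within the scatter of two such steps. This shows that the change behaved alike on the two cores, in that neither pair gives a measurable effect, but it does not show that the change has any real effect to carry over, and two pairs say nothing about other cores or other places on the aromatic ring.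

The compounds shown carry only fluoro on the benzyl arm, which leaves open what a chloro, methoxy or trifluoromethyl group would do in its place on either core. Also open, as far as these compounds go, is whether an amine, a carboxylic acid or a longer chain on that arm would move the number beyond the scatter in this cell assay.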